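The source may hold more compounds than are shown below. What is called first, only, known or untested is meant among the compounds shown, and "the series" means these compounds.

Working notes on the naphthyl amide series.

In an assay on LtK cells with ATP-sensitive inward rectifier potassium channel 11 (Homo sapiens) as the target (on this read-out higher numbers stand for an effect only at larger amounts of compound and lower numbers for an effect already at smaller amounts), compound 1 `CC(C)OC(=O)Nc1c(C(O)(C(F)(F)F)C(F)(F)F)ccc2ccccc12` gives 1160 nM, and compound 2 `O=C(Nc1c(C(O)(C(F)(F)F)C(F)(F)F)ccc2ccccc12)c1cccc(Br)c1` gives 80 nM. Within the data shown here, compound 2 thus stands at the lowest of the two numbers so far, with compound 1 as its only neighbour at a clearly higher value. Among the measured compounds shown here, the single measured step, a 15-fold lower number from compound 1 to compound 2 (1.16 log units; beyond the scatter), replaces the isopropoxy on the carbonyl carbon with a 3-bromophenyl and is large. Compound 3 `O=C(Nc1c(C(O)(C(F)(F)F)C(F)(F)F)ccc2ccccc12)c1cccc(C(F)(F)F)c1` keeps that 3-bromophenyl amide and alters only its substituent: trifluoromethyl in place of bromo on an aromatic carbon. For the measured compounds named here, no measured step touches the substituent on this phenyl ring, so the one step available does not bear directly on the change; the carbonyl-side alteration that it reports is of a different kind. With nothing in the series speaking for a shift, compound 3 is expected to land close to compound 2, the step of a 1.3-fold higher number from compound 2 to compound 3 (0.10 log units; within the scatter) being estimated as within the scatter. Compound 3 is therefore estimated at 100 nM, with a range from 40 nM to 250 nM.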

Compound 3, half-maximal effective concentration: 84 nM
Compound 3: the middle estimate sits 1.2-fold (0.08 log units) above what was measured; the range from low to high includes it.
By their numbers in this assay, from the lowest: compounds 2 and 3 (each within the scatter of the next); then compound 1.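

In this assay, trifluoromethyl in place of bromo on this aromatic carbon gives a 1.1-fold higher number from compound 2 to compound 3 (0.02 log units; within the scatter), so the readout does not separate the two groups at this place, although four heavy atoms enter where one leaves. The large step away from isopropoxy on the carbonyl carbon also holds with the new aryl group, at a 14-fold lower number from compound 1 to compound 3 (1.14 log units; beyond the scatter), so across these compounds it is not tied to bromo. Nothing measured on these compounds accounts for the match between bromo and trifluoromethyl.

The compounds shown leave open whether an amine or a carboxylic acid on this aromatic carbon would keep the number at this level, and what plain hydrogen there would do. They also leave open how a longer alkyl chain in place of isopropoxy on the carbonyl carbon would compare.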